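Trading a sulfonyl group for a sulfanyl group

This account rests on a few compounds, and the source may have more. Where it says the series, first, only, none or still open, it means among the compounds named here.

In a functional assay on DU-145 cells (Homo sapiens) for inhibition, read by trypan blue exclusion, with a stated time of 96 h (a higher number here means a weaker inhibitor of growth, a lower number a stronger inhibitor of growth), compound 1 `Cc1ccc(S(=O)(=O)/C(=C/c2ccc(O)c([N+](=O)[O-])c2)C(=O)c2ccc(Cl)cc2)cc1` gives 25000 nM, compound 2 `Cc1ccc(S(=O)(=O)/C(=C/c2sccc2C)C(=O)c2ccc(Cl)cc2)cc1` gives 10000 nM and compound 3 `Cc1ccc(CS/C(=C/c2c(O)cc(O)cc2O)C(=O)c2ccc(Cl)cc2)cc1` gives 50000 nM. Compound 1 and compound 3 lie within the scatter of each other, while compound 2 stands apart: a 2.5-fold lower number from compound 1 to compound 2 (0.40 log units; beyond the scatter). Compound 4 `O=C(/C(=C\c1ccc(O)c([N+](=O)[O-])c1)SCc1ccc(Cl)cc1)c1ccc(Cl)cc1` carries (4-chlorobenzyl)sulfanyl in place of (4-methylphenyl)sulfonyl on a double-bonded chain carbon bound to a carbonyl carbon and a double-bonded chain carbon. Among the measured compounds shown here, the one measured step changes a different group, so it shows only how large a single change can be here. Compound 3, which also has a sulfanyl group at that place, gives 50000 nM. No step beyond the scatter is therefore expected in this assay. For compound 4 the estimated value is 30000 nM, with an expected range of 10000 nM to 80000 nM.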

Compound 4, concentration for 50% growth inhibition: 10000 nM
For compound 4 the middle estimate is 3.0-fold (0.48 log units) above the measured one, within the range that was stated.
By their numbers in this assay, from the lowest: compounds 2 and 4 (each within the scatter of the next); then compounds 1 and 3 (each within the scatter of the next).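

In this assay, among the compounds shown here, this swap gives a 2.5-fold lower number from compound 1 to compound 4 (0.40 log units; beyond the scatter), the first measured change at this place. On the core of compound 1, then, the (4-methylphenyl)sulfonyl group is not required for growth inhibition, and (4-chlorobenzyl)sulfanyl serves at least as well. The swap alters the sulfur group, the link to the ring and the ring's substituent all at once, so this one step cannot separate them. Going by these compounds, whether an amine or a longer chain would be tolerated at this place remains open. Nothing measured here accounts for the step.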